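The source may hold more compounds than are shown below. What is called first, only, known or untested is meant among the compounds shown, and "the series" means these compounds.

Measured in an ADME assay on microsomes from liver (Rattus norvegicus) for metabolic stability; a lower number here means that the compound disappears faster, a higher number that the compound lasts longer:
- compound 1 `COc1cc(OCc2csc(-c3ccc(C(F)(F)F)cc3)n2)c2cc(-c3cn4nc(OC)sc4n3)oc2c1`: 1.42 h
- compound 2 `COc1cc(OCc2cccc(-c3cnc(OC)cn3)c2)c2cc(-c3cn4nc(OC)sc4n3)oc2c1`: 1.62 h
- compound 3 `COc1cc(OCc2cccc(-c3cncnc3)c2)c2cc(-c3cn4nc(OC)sc4n3)oc2c1`: 0.117 h

In this assay, compound 1 at 1.42 h and compound 2 at 1.62 h lie within the usual scatter of each other. Compound 3 at 0.117 h lies far lower than both, beyond the scatter.

The next compound is compound 4 `COc1cc(OCc2csc(-c3ccccc3)n2)c2cc(-c3cn4nc(OC)sc4n3)oc2c1`, which differs from compound 1 by hydrogen in place of trifluoromethyl on an aromatic carbon, so that 4-(trifluoromethyl)phenyl becomes phenyl. Among the measured compounds shown here, no measured step removes trifluoromethyl. For the measured compounds named here, the only step available is a 14-fold lower number from compound 2 to compound 3 (1.14 log units; beyond the scatter), a large one, with pyrimidin-5-yl in place of 5-methoxypyrazin-2-yl on an aromatic carbon. It is a different exchange on a different side group, so it carries over only loosely. It shows that the number in this assay can respond strongly to an exchange on the aromatic end of this side group, and that its one measured response was downward. A lower number is therefore expected for compound 4, though by much less than that step. The expected change is a 1.8-fold lower number from compound 1 to compound 4 (0.25 log units; within the scatter). For compound 4 the estimated half-life is 0.8 h, with an expected range of 0.25 h to 1.8 h.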

Compound 4, half-life: 1.22 h
The estimate for compound 4 lay 1.5-fold (0.18 log units) below the measured number; the measured number falls inside the stated range.
By their numbers in this assay, from the lowest: compound 3; then compounds 4, 1 and 2 (each within the scatter of the next).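

In this assay, the exchange of 4-(trifluoromethyl)phenyl for phenyl gives a 1.2-fold lower number from compound 1 to compound 4 (0.07 log units; within the scatter), so at this place, on a six-membered aromatic ring of carbon only and para to a large group, trifluoromethyl can be replaced by hydrogen without a change that stands out from the scatter. Among the compounds shown here, this is the first reading of an exchange on this side group, and it shows that the half-life of the series is not held up by trifluoromethyl here. The side group of compound 2 and compound 3 responded very differently to its own exchange, with a 14-fold lower number from compound 2 to compound 3 (1.14 log units; beyond the scatter), so a large response at the aromatic end is not general across the side groups shown. No measured property of either group bears on this result, and no reason for it can be offered.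

The compounds shown compare only hydrogen and trifluoromethyl at this place, so it remains open whether an amine, a carboxylic acid or a longer chain there would leave the half-life equally unmoved. As far as these compounds go, it also remains open whether the same exchange of trifluoromethyl for hydrogen would read the same way on another side group of the series.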